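The compounds below may be only part of what the source reports. "The series", "measured", "known", "first", "only" and "open" are said of these compounds alone.

Three compounds of a shared core are set down here. Compound 1 `Cc1ccccc1S(=O)(=O)N1CCC(CCCC(=O)NO)CC1` carries a methyl-substituted arylsulfonyl group; compound 2 `O=C(CCCC1CCN(S(=O)(=O)Nc2ccccc2)CC1)NO` carries a sulfamoyl linked through nitrogen to a phenyl ring; compound 3 `O=C(CCCC1CCN(S(=O)(=O)c2ccc(C(F)(F)F)cc2)CC1)NO` carries an arylsulfonyl group bearing trifluoromethyl. In a functional assay on HCT-116 cells (Homo sapiens) for inhibition, read by resazurin assay, with a stated time of 5 days (a lower number here means a stronger inhibitor of growth, a higher number a weaker inhibitor of growth), compound 2 gives 2000 nM. For compound 1 in this assay the entry is "not determined" (no result reported), and for compound 3 the entry in this assay is "not determined" (no result reported): it stands without a single number, so nothing can be said of where it sits against compound 2.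

Compound 4 `O=C(CCCC1CCN(S(=O)(=O)c2ccccc2)CC1)NO` is the next compound and has yet to be tested in this assay. It differs from compound 3 in one place: hydrogen in place of trifluoromethyl on an aromatic carbon. Among the compounds with values here, since compound 3 has no value in this assay, no measured step leads to compound 4, and the expectation must rest on compound 2 alone. With compound 2 at 2000 nM as the only anchor, and the change from compound 3 being the loss of a single substituent, the account does not expect compound 4 to move beyond the usual scatter from that anchor in either direction. Compound 4 is therefore estimated at 2000 nM in this assay, with a range from 500 nM to 8000 nM.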

Compound 4, concentration for 50% growth inhibition: 2700 nM
Estimate against measurement, compound 4: 1.4-fold (0.13 log units) below, within the range that was stated.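

In this assay, the sulfonyl sulfur of the shared core now has two measured groups to compare, and the exchange of anilino for phenyl at this position gives a 1.4-fold higher number from compound 2 to compound 4 (0.13 log units; within the scatter). For this one pair, then, the anilino nitrogen that links the aromatic ring to the sulfonyl sulfur can be replaced by a direct attachment of phenyl with no separation of the two compounds in growth inhibition, and neither compound can be placed ahead of the other. Nothing in hand offers a measured explanation of this result.

On these data alone, the steps from compound 1 and compound 3 to compound 4 cannot be read, so the effect of a methyl or a trifluoromethyl on the aromatic ring remains unknown. The compounds shown also leave open how the growth-inhibition number of compound 4 would respond to an amine or a carboxylic acid on that ring, or to a longer chain in place of the phenyl on the sulfonyl sulfur.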